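The source may hold more compounds than are shown below. What is called first, only, known or untested is meant among the compounds shown, and "the series" means these compounds.

Compound 1 `O=C1Nc2ccc(Br)cc2C1=Cc1ccncc1`: 22300 nM
Compound 2 `O=C1Nc2ccc(Br)cc2C1=Cc1cccs1`: 427000 nM
Compound 3 `O=C1Nc2ccc(Br)cc2C1=Cc1ccco1`: 449000 nM

In an ADME assay on A549 cells (Homo sapiens) for cytotoxicity, read by MTT assay, with a stated time of 72 h (a higher number here means a weaker inhibitor, a lower number a stronger inhibitor), compound 1 gives 22300 nM, the lowest number of the three. Compound 4 `O=C1Nc2ccc([N+](=O)[O-])cc2C1=Cc1ccncc1` keeps the pyridin-4-yl group of compound 1 but has nitro in place of bromo on an aromatic carbon. Among the measured compounds shown here, all the measured steps change a different group. Two are large, a 19-fold higher number from compound 1 to compound 2 (1.28 log units; beyond the scatter) and a 20-fold higher number from compound 1 to compound 3 (1.30 log units; beyond the scatter), while a 1.1-fold higher number from compound 2 to compound 3 (0.02 log units; within the scatter) lies within the scatter. None of them replaces the bromo group, so they give no size for this change, and no step beyond the scatter is expected in this assay. The expected step is a 1.1-fold lower number from compound 1 to compound 4 (0.05 log units; within the scatter). For compound 4 the estimated value is 20000 nM, with an expected range of 6000 nM to 70000 nM.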

Compound 4, half-maximal inhibitory concentration: "not toxic" (no number reported)
Compound 4: no number reported; no gap can be computed for the estimate.
By their numbers in this assay, from the lowest: compound 1; then compounds 2 and 3 (each within the scatter of the next).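

Among the compounds shown here, compound 4 is reported only as "not toxic", with no number, so no step from compound 1 to compound 4 can be read. On these data alone, how far nitro in place of bromo shifts the number stays open. No evidence available bears on this result.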